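Substituent on the ketone ring: methoxy out, chlorine in

The source may report more compounds than this note shows. Statements on the series, on what has been measured and on what is new or still open speak of the compounds shown alone.

Compound 3 `COc1ccc(Nc2nc(N)c(C(=O)c3cccc(OC)c3)s2)cc1` gives 4 nM in a functional assay on MOLT-4 cells (Homo sapiens) for antiproliferative activity, read by cell counting, with a stated time of 2 days (on this read-out lower numbers stand for stronger inhibition and higher numbers for weaker inhibition), the lowest of the three numbers in hand. Compound 1 `COc1ccc(Nc2nc(N)c(C(=O)c3ccccc3OC)s2)cc1` gives 18 nM and compound 2 `COc1ccc(Nc2nc(N)c(C(=O)c3ccccc3)s2)cc1` gives 230 nM. The steps between them are a 58-fold lower number from compound 2 to compound 3 (1.76 log units; beyond the scatter), a 13-fold higher number from compound 1 to compound 2 (1.11 log units; beyond the scatter) and a 4.5-fold lower number from compound 1 to compound 3 (0.65 log units; beyond the scatter). Compound 4 `COc1ccc(Nc2nc(N)c(C(=O)c3ccc(Cl)cc3)s2)cc1` differs from compound 3 by 4-chlorophenyl in place of 3-methoxyphenyl on a carbonyl carbon. For the measured compounds named here, the step from compound 2 to compound 3 bears most directly, since compound 4 likewise carries no methoxy on that ring; the chlorine has no measured precedent in this set, so its own contribution is unknown. For compound 4 the expected step is a 25-fold higher number from compound 3 to compound 4 (1.40 log units; beyond the scatter), a higher number beyond the scatter. Compound 4 is estimated at 100 nM, with a range from 20 nM to 500 nM.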

Compound 4, half-maximal inhibitory concentration: 13 nM
Estimate against measurement, compound 4: 7.7-fold (0.89 log units) above; measured number outside the range, below it.
By their numbers in this assay, from the lowest: compound 3; then compounds 4 and 1 (each within the scatter of the next); then compound 2.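

On the ketone ring, chloro in place of hydrogen gives a large gain (an 18-fold lower number from compound 2 to compound 4 (1.25 log units; beyond the scatter)) in this assay, so this position does not need a methoxy for a large step from the unsubstituted ring. Against the two methoxy rings the picture splits: 4-chlorophenyl gives a 3.3-fold higher number from compound 3 to compound 4 (0.51 log units; beyond the scatter) but, against 2-methoxyphenyl, a 1.4-fold lower number from compound 1 to compound 4 (0.14 log units; within the scatter). No supporting data bear on why these steps take these sizes.

Open: how a ketone ring carrying trifluoromethyl, a nitrile or an amine in place of chloro would read, and whether chloro and methoxy together on one ring would go beyond compound 3.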